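The source may report more compounds than this note shows. Statements on the series, on what has been measured and on what is new or still open speak of the compounds shown alone.

Three compounds with a shared core, `Cc1ccc(S(=O)(=O)NC(=O)Nc2ccccc2C(=O)/C=C/c2ccc(O)cc2)cc1` for compound 1, `Cc1ccc(S(=O)(=O)NC(=O)Nc2ccccc2C(=O)/C=C/c2cc(O)ccc2[N+](=O)[O-])cc1` for compound 2 and `Cc1ccc(S(=O)(=O)NC(=O)Nc2ccccc2C(=O)/C=C/c2cccc(Br)c2)cc1` for compound 3, have been tested in an ADME assay on the whole organism for cytotoxicity, with Artemia salina as the target, with a stated time of 24 h; on this read-out higher numbers stand for an effect only at larger amounts of compound and lower numbers for an effect already at smaller amounts. Compound 1 gives 24.3 ug/mL, compound 2 gives 18.3 ug/mL and compound 3 gives 4.02 ug/mL, the lowest number of the three. Compound 4, `Cc1ccc(S(=O)(=O)NC(=O)Nc2ccccc2C(=O)/C=C/c2ccncc2)cc1`, is not yet measured; it differs from compound 3 by pyridin-4-yl in place of 3-bromophenyl on a double-bonded chain carbon bound to a double-bonded chain carbon. Two earlier steps changed the same ring: a 6.0-fold lower number from compound 1 to compound 3 (0.78 log units; beyond the scatter) and a 4.6-fold lower number from compound 2 to compound 3 (0.66 log units; beyond the scatter), each a modest move downward when 3-bromophenyl entered. Since that ring is now changed again, a move back upward, beyond the scatter, is expected, roughly a 3.0-fold higher number from compound 3 to compound 4 (0.47 log units; beyond the scatter). The estimate for compound 4 in this assay is therefore 12 ug/mL, between 4 ug/mL and 35 ug/mL.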

Compound 4, concentration for half-maximal effect: 16.8 ug/mL
Beside the measured number, compound 4's estimate is 1.4-fold (0.15 log units) below it, within the range that was stated.
By their numbers in this assay, from the lowest: compound 3; then compounds 4, 2 and 1 (each within the scatter of the next).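

In this assay, this position now shows a rise as well as a fall: the ring swap gives a 4.2-fold higher number from compound 3 to compound 4 (0.62 log units; beyond the scatter), so the low number does not persist once 3-bromophenyl leaves. Pyridin-4-yl, with no hydroxyl or nitro group, also lands level with the two earlier rings, at a 1.1-fold lower number from compound 2 to compound 4 (0.04 log units; within the scatter) and a 1.4-fold lower number from compound 1 to compound 4 (0.16 log units; within the scatter), leaving compound 3 alone among the four. No measured evidence explains this. Still open, on these data alone, is whether the low number of compound 3 goes with the bromine itself or with its place on the ring. A plain phenyl or a 4-bromophenyl ring on this carbon would speak to that.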